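The source may report more compounds than this note shows. Statements on the series, on what has been measured and on what is new or still open speak of the compounds shown alone.

Compound 1 `CSc1ncnc2c1c(-c1ccccc1)cn2[C@@H]1O[C@H](CO)[C@@H](O)[C@H]1O` and compound 3 `CSc1ncnc2c1c(-c1cccs1)cn2[C@@H]1O[C@H](CO)[C@@H](O)[C@H]1O` share one core, while compound 2 `Nc1nc(N)c2c(-c3ccccc3)cn([C@@H]3O[C@H](CO)[C@@H](O)[C@H]3O)c2n1` and the still unmeasured compound 4 `Nc1nc(N)c2c(-c3cccs3)cn([C@@H]3O[C@H](CO)[C@@H](O)[C@H]3O)c2n1` share another; the difference between the two cores is not broken down here. In a functional assay on K562 cells (Homo sapiens), read by MTT assay, with a stated time of 72 h (on this read-out lower numbers stand for stronger inhibition and higher numbers for weaker inhibition), compound 1 gives only a limit of the assay, > 20000 nM. Compound 3 gives 11600 nM in this assay. The change thiophen-2-yl in place of phenyl on an aromatic carbon therefore made an at least 1.7-fold lower number from compound 1 to compound 3 (0.23 log units; that floor lies within the scatter), a step whose floor follows from the limit of > 20000 nM in this assay, at which 2 of the 3 values shown sit. In this assay compound 2 also gives only a limit of the assay, > 20000 nM. Compound 4 carries the same change, (thiophen-2-yl in place of phenyl on an aromatic carbon), at a place described in identical words. Among the measured compounds shown here, compound 4 is expected to show an at least 1.3-fold lower number from compound 2 to compound 4 (0.12 log units; that floor lies within the scatter) because an at least 1.7-fold lower number from compound 1 to compound 3 (0.23 log units; that floor lies within the scatter) is the only earlier instance of this change and lies within the scatter. The estimate for compound 4 is 15000 nM, between 7000 nM and 40000 nM.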

Compound 4, half-maximal inhibitory concentration: > 20000 nM
Compound 4: a limit, no number (the forecaster's own chance of this, stated with the estimate: 45%); middle value at least 1.3-fold (0.12 log units) away from the limit.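

No step can be read between compound 2 and compound 4, because both give only a limit: the limit of > 20000 nM in this assay, at which 3 of the 4 values shown sit.

The compounds shown leave open what thiophen-2-yl in place of phenyl does on the core of compound 2.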